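The source may report more compounds than this note shows. Statements on the series, on what has been measured and on what is new or still open speak of the compounds shown alone.

Measured compounds:
- compound 1, `CCCN(CC[C@H](N)C(=O)O)C[C@H]1O[C@@H](n2cnc3c(N)ncnc32)[C@H](O)[C@@H]1O`: no result reported in an assay for inhibition of tRNA (cytosine(38)-C(5))-methyltransferase (Homo sapiens), with a stated time of 5 min, tested at 100 uM; a lower number here means less inhibition, a higher number more inhibition at the concentration tested (going by the name of the read-out)
- compound 2, `Nc1ncnc2c1ncn2[C@@H]1O[C@H](CN(CC[C@H](N)C(=O)O)CC2CC2)[C@@H](O)[C@H]1O`: 27.5%
- compound 3, `CCC#CCN(CC[C@H](N)C(=O)O)C[C@H]1O[C@@H](n2cnc3c(N)ncnc32)[C@H](O)[C@@H]1O`: 62.8%

Compound 3 stands highest of the two numbers recorded in this assay; its nearest neighbour, compound 2, sits a step below it that is beyond the scatter, and compound 1 carries no number at all. Among the compounds with values here, the single step that can be read from the measured pairs is a number 35.3 percentage points higher from compound 2 to compound 3 (beyond the scatter), a large gain on exchanging a ring for an open alkynyl chain on the saturated chain carbon bound to the amine nitrogen.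

Compound 4, `Nc1ncnc2c1ncn2[C@@H]1O[C@H](CN(CC[C@H](N)C(=O)O)Cc2ccccc2)[C@@H](O)[C@H]1O`, differs from compound 3 only at that same position: phenyl in place of but-1-yn-1-yl on a saturated chain carbon bound to an amine nitrogen. Within the data shown here, the one measured step bears on it only loosely, since it compares an open chain against a small saturated ring, while here an aromatic ring replaces the open chain; it says nothing direct about a phenyl at this place. Given that the alkynyl chain of compound 3 gave the higher number and compound 2 shows the lower number with a ring, the expectation for compound 4 is a step downward of moderate size, a number 14.8 percentage points lower from compound 3 to compound 4 (beyond the scatter), with wide uncertainty. In this assay compound 4 is therefore expected to give about 48%, estimated to lie between 25% and 72%.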

Compound 4, a percentage reported as inhibition, at one concentration (the size of the read-out at that concentration, not a potency): 56.8%
The estimate for compound 4 lay 8.8 percentage points below the measured number; low and high end bracket the measured number.
By their numbers in this assay, from the lowest: compound 2; then compounds 4 and 3 (each within the scatter of the next).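

In this assay the change from but-1-yn-1-yl to phenyl on a saturated chain carbon bound to an amine nitrogen gives a number 6 percentage points lower from compound 3 to compound 4 (within the scatter) and so leaves the two groups undistinguished; an open chain with a triple bond and a six-membered aromatic ring of carbon only are both compatible with a number at this level. The earlier step could be read as a preference for an open chain over a ring, but the change from cyclopropyl to phenyl gives a number 29.3 percentage points higher from compound 2 to compound 4 (beyond the scatter) and shows that a ring at this place does not by itself go with the lower number, leaving the cyclopropyl member alone apart from the other two. Nothing available explains why cyclopropyl stands apart from but-1-yn-1-yl and phenyl at this place.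

Steps involving compound 1 cannot be read, so the propyl group offers no saturated open chain for comparison with but-1-yn-1-yl. Still open, on these data alone, is whether the number holds with a longer chain in place of the phenyl, or with a phenyl ring carrying a substituent such as an amine or a carboxylic acid.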